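Swapping Methoxy for Chloro at a Solubility Limit

The source may hold more compounds than are shown below. What is called first, only, known or untested is meant among the compounds shown, and "the series" means these compounds.

Of the compounds shown here, two have been measured so far, and neither gives an exact number. Compound 1 (`Cc1[nH]c2ccccc2c(=O)c1/C=C/c1ccc(O)cc1`) gives > 20000 nM in a physicochemical assay for solubility, read by HPLC, at pH 7.4 (on this read-out higher numbers stand for higher solubility and lower numbers for lower solubility), which is a limit of the assay and not a number. Compound 2 (`COc1ccc2[nH]c(C)c(Br)c(=O)c2c1`) gives > 20000 nM in this assay, which is likewise only a limit. The record so far therefore amounts to the limit of > 20000 nM in this assay, at which 2 of the 2 values shown sit, and compound 2 stands there with no exact value as a starting point.

The next compound is compound 3 (`Cc1[nH]c2ccc(Cl)cc2c(=O)c1Br`), in which chloro takes the place of methoxy on an aromatic carbon of the shared core: chloro in place of methoxy on an aromatic carbon. Within the data shown here, no step between measured compounds is available to size this change in this assay. A modest downward move is expected, though a reading that again returns only a limit remains quite possible. The step expected is an at least 1.3-fold lower number from compound 2 to compound 3 (0.12 log units; that floor lies within the scatter). For compound 3 the estimated solubility is 15000 nM, with an expected range from 5000 nM to 30000 nM.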

Compound 3, solubility: 5000 nM
The estimate for compound 3 lay 3.0-fold (0.48 log units) above the measured number; the range from low to high includes it.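

Among these compounds, with compound 3, the record of this series holds an exact number in this assay for the first time, where before it held only limits. Chloro in place of methoxy on this aromatic carbon, meta to a fused ring and para to a fused ring, comes with an at least 4.0-fold lower number from compound 2 to compound 3 (0.60 log units; beyond the scatter), so this single exchange shows that the read-out at this place can move by more than ordinary repeat variation. The step can be given only as a minimum and its full size remains unknown, because compound 2 offers no exact number to start from: the limit of > 20000 nM in this assay, at which 2 of the 3 values shown sit.

With a single exchange at this place, the compounds shown do not separate what the arrival of chloro contributes from what the departure of methoxy removes, and they do not show whether the step would be the same on another core. They also leave open how an amine, a carboxylic acid or a longer chain on the same aromatic carbon would read in this assay, and whether any of these would return an exact number or a limit.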